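The source may hold more compounds than are shown below. What is called first, only, known or untested is meant among the compounds shown, and "the series" means these compounds.

Compound 1 `COc1ccc(C(=O)/C=C/c2cc(-c3cc(OC)c(OC)c(OC)c3)n[nH]2)cc1OC` and compound 2 `COc1ccc(C(=O)/C=C/c2cc(-c3cc(OC)c(OC)c(OC)c3)n[nH]2)cc1` share a core and differ only by a hydrogen in place of methoxy on an aromatic carbon. In a functional assay on COLO 205 cells (Homo sapiens) for cytotoxicity, read by sulforhodamine B assay, with a stated time of 48 h, tested at 100 uM (a higher number here means a weaker effect of the compound at the concentration tested, a lower number a stronger effect), compound 1 gives -75%, and compound 2 gives -81%. The step of a number 6 percentage points lower from compound 1 to compound 2 (within the scatter) lies within the scatter, so compound 2 stands at the lowest of the two numbers without being separated from compound 1. Compound 3 `COc1cc(-c2cc(/C=C/C(=O)c3ccc(F)c(F)c3)[nH]n2)cc(OC)c1OC` differs from compound 2 by 3,4-difluorophenyl in place of 4-methoxyphenyl on a carbonyl carbon. Among the compounds with values here, no measured step concerns the group on the carbonyl carbon; the only step known, from compound 1 to compound 2, was within the scatter and touched another part of the molecule. He therefore expects for compound 3 a step of a number 9 percentage points higher from compound 2 to compound 3 (within the scatter), which is no clear move beyond the scatter in either direction. His estimate for compound 3 in this assay is -72%, within a range from -92% to -35%.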

Compound 3, a percentage reported as activity, at one concentration (the size of the read-out at that concentration, not a potency): -99%
Compound 3: middle estimate off by 27 percentage points, on the high side; the whole stated range lies above it.
By their numbers in this assay, from the lowest: compound 3; then compounds 2 and 1 (each within the scatter of the next).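

In this assay, the group on the carbonyl carbon proves to be a position that responds: 3,4-difluorophenyl in place of 4-methoxyphenyl gives a number 18 percentage points lower from compound 2 to compound 3 (beyond the scatter), and 3,4-difluorophenyl in place of 3,4-dimethoxyphenyl gives a number 24 percentage points lower from compound 1 to compound 3 (beyond the scatter). These are the first steps beyond the scatter among these compounds, whereas hydrogen in place of methoxy on an aromatic carbon gave only a number 6 percentage points lower from compound 1 to compound 2 (within the scatter), so compound 3 is separated from both of the others. Nothing available accounts for this difference.

The three compounds leave open whether the fluorines themselves or the absence of methoxy carry the step, which a plain phenyl or a 4-fluorophenyl group on the carbonyl carbon would help to separate. Going by these compounds, how a 4-aminophenyl or 4-carboxyphenyl group would behave there also remains open, and each read-out gives only the size of the effect at a single concentration.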